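A few compounds are considered here, and "the series" means these few. Any claim that something is new, unique, unknown or untested is made for them only; others in the source may bear on it.

Measured compounds in an assay on microsomes from brain for inhibition of Fatty-acid amide hydrolase 1 (Rattus norvegicus), read by fluorescence and HPLC, with a stated time of 60 min; on this read-out lower numbers stand for stronger inhibition and higher numbers for weaker inhibition:

Compound 1, `CCCCCCCCc1ccc(OCC(=O)Cn2nnc(SC)n2)cc1`: 31 nM
Compound 2, `CCCCCCCCc1ccc(OCC(=O)Cn2nnc(C(=O)O)n2)cc1`: 41 nM
Compound 3, `CCCCCCCCc1ccc(OCC(=O)Cn2nnnc2SC)cc1`: 22 nM

Compound 3 gives the lowest of the three numbers in this assay, but its distances to the others are small: a 1.4-fold lower number from compound 1 to compound 3 (0.15 log units; within the scatter) and a 1.9-fold lower number from compound 2 to compound 3 (0.27 log units; within the scatter), so the three compounds cannot be set apart from one another.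

Compound 4, `CCCCCCCCc1ccc(OCC(=O)Cn2nnnc2-c2ccncc2)cc1`, is not yet measured. It keeps the shared core of compound 3 and differs only at one spot: pyridin-4-yl in place of methylsulfanyl on an aromatic carbon.

For the measured compounds named here, only one measured step concerns the group on an aromatic carbon of this five-membered ring: a 1.3-fold higher number from compound 1 to compound 2 (0.12 log units; within the scatter). There, a carboxy group replaced methylsulfanyl without a difference beyond the scatter. Going by the values given here, no measured step involves a six-membered aromatic ring at this position, so the new change is larger than anything seen so far. On the evidence at hand, the expected step is a 1.4-fold higher number from compound 3 to compound 4 (0.13 log units; within the scatter), that is, nothing clearly beyond the scatter, with a wide range to cover the untested ring.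

Compound 4 is therefore estimated at 30 nM in this assay, in a range from 9 nM to 100 nM.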

Compound 4, half-maximal inhibitory concentration: 190 nM
Compound 4: the middle estimate sits 6.3-fold (0.80 log units) below what was measured, outside the stated range (above it).
By their numbers in this assay, from the lowest: compounds 3, 1 and 2 (each within the scatter of the next); then compound 4.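

In this assay, for the compounds shown here, the aromatic carbon between two ring nitrogen atoms proves sensitive to what it carries, as pyridin-4-yl in place of methylsulfanyl gives an 8.6-fold higher number from compound 3 to compound 4 (0.94 log units; beyond the scatter) and this is the first step in the set beyond the scatter. The earlier swap of methylsulfanyl for carboxy on a five-membered ring with 4 nitrogen gave only a 1.3-fold higher number from compound 1 to compound 2 (0.12 log units; within the scatter) and so showed no such sensitivity, which means that the group at this carbon can matter after all. Nothing available here accounts for the higher number.

The compounds shown leave open whether the change follows from the six-membered ring itself or from its ring nitrogen, a question that a phenyl group at this carbon would help to answer. They also leave open how an amine or a longer chain would fare here.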